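Swapping Methoxy for Carboxy in a Kinase Inhibitor Series

The source may hold more compounds than are shown below. What is called first, only, known or untested is meant among the compounds shown, and "the series" means these compounds.

Compound 1, `CC(=O)c1ccc(OCC(=O)Nc2cccc(NC(=O)c3ccc(N(C)C)cc3)c2)cc1F`: 98 nM
Compound 2, `COc1ccc(C(=O)Nc2cccc(NC(=O)COc3ccc4c(=O)ccoc4c3)c2)cc1`: 7 nM

Of the compounds shown here, two have so far been tested in an assay on isolated protein for inhibition of Rho-associated protein kinase 2 (Homo sapiens), read by scintillation counting, radiometric assay and 33P incorporation, with a stated time of 40 min, in the presence of a further agent that is not named here; on this read-out lower numbers stand for stronger inhibition and higher numbers for weaker inhibition. Compound 1 gives 98 nM, while compound 2 gives 7 nM. Compound 2 therefore holds the lowest number of the two, and its gap to compound 1 lies beyond the usual scatter of this assay, so compound 2 is the stronger inhibitor of the pair.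

Compound 3, `O=C(COc1ccc2c(=O)ccoc2c1)Nc1cccc(NC(=O)c2ccc(C(=O)O)cc2)c1`, has not yet been measured. It differs from compound 2 in one place: carboxy in place of methoxy on an aromatic carbon. Within the data shown here, no measured pair shows this exact change, so there is nothing to lean on directly. The expectation is a modest step toward a higher number, a 4.3-fold higher number from compound 2 to compound 3 (0.63 log units; beyond the scatter), that is, somewhat weaker inhibition, though the change could also end up within the scatter. Compound 3 is therefore estimated at 30 nM, with a likely range from 7 nM to 120 nM.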

Compound 3, half-maximal inhibitory concentration: 2030 nM
Estimate against measurement, compound 3: 68-fold (1.83 log units) below, outside the stated range (above it).
By their numbers in this assay, from the lowest: compound 2; then compound 1; then compound 3.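

In this assay the change from the 4-methoxyphenyl to the 4-carboxyphenyl group gives a 290-fold higher number from compound 2 to compound 3 (2.46 log units; beyond the scatter) and so much weaker inhibition. Among these compounds, compound 1 and compound 2 differ in more than one place, so only this new pair isolates a single group, on an aromatic carbon para to a large group, and shows how strongly the number depends on what sits there. Nothing available here accounts for the size of this step.

The compounds shown do not reveal how other groups would fare at this place, such as an amine, a primary amide or a methyl ester, so the tolerance of this position remains unmapped. They also leave open whether the same swap would cost as much on a different core, such as that of compound 1.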